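The source may hold more compounds than are shown below. What is called first, only, known or untested is meant among the compounds shown, and "the series" means these compounds.

Compound 1 `COc1cc(-c2nn(-c3cccc(NC(=O)Nc4ccc(Cl)c(Cl)c4)c3)cc2-c2ccncc2)ccc1Cl` and compound 2 `COc1cc(-c2nn(-c3cccc(NC(=O)c4ccc(Cl)c(C(F)(F)F)c4)c3)cc2-c2ccncc2)ccc1Cl` share one core. In a functional assay on HCC 2998 cells (Homo sapiens) for inhibition, read by sulforhodamine B assay, with a stated time of 48 h (on this read-out higher numbers stand for weaker inhibition of growth and lower numbers for stronger inhibition of growth), compound 1 gives 1560 nM and compound 2 gives 7860 nM, the higher of the two numbers. Among the compounds with values here, the one measured step, a 5.0-fold higher number from compound 1 to compound 2 (0.70 log units; beyond the scatter), replaced a urea link by an amide while also changing the ring substituents. Compound 3 `COc1cc(-c2nn(-c3cccc(NC(=O)Nc4ccc(Cl)c(C(F)(F)F)c4)c3)cc2-c2ccncc2)ccc1Cl` restores the urea: (4-chloro-3-(trifluoromethyl)phenyl)amino in place of 4-chloro-3-(trifluoromethyl)phenyl on a carbonyl carbon. Within the data shown here, because the only guide is the step of a 5.0-fold higher number from compound 1 to compound 2 (0.70 log units; beyond the scatter), compound 3 is expected to move back toward compound 1 in this assay, a step of roughly a 4.4-fold lower number from compound 2 to compound 3 (0.64 log units; beyond the scatter). Compound 3 is estimated at 1800 nM, between 700 nM and 4500 nM.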

Compound 3, concentration for 50% growth inhibition: 1550 nM
Estimate against measurement, compound 3: 1.2-fold (0.06 log units) above; the measured number falls inside the stated range.
By their numbers in this assay, from the lowest: compounds 3 and 1 (each within the scatter of the next); then compound 2.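

In this assay, with the ring substituents held fixed, the urea in place of the amide gives a 5.1-fold lower number from compound 2 to compound 3 (0.71 log units; beyond the scatter) on the carbonyl carbon, a change in the link alone that the earlier step, which also changed the ring, could not separate. Trifluoromethyl in place of chloro on an aromatic carbon gives a 1.0-fold lower number from compound 1 to compound 3 (0.00 log units; within the scatter) and so shows no separable difference between these two ring substituents in this read-out. No measurement here explains the difference between urea and amide.

Going by these compounds, whether the urea hydrogen itself matters stays open. A methyl group on that urea nitrogen or a thiourea link could help to test this.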